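The source may hold more compounds than are shown below. What is called first, only, known or untested is meant among the compounds shown, and "the series" means these compounds.

Measured compounds:
Compound 1 `Cc1cccc(Cn2c(CN3CCN(C(=O)c4cccnc4)CC3)nc3ccccc32)c1` gives 24.5% in an assay on isolated protein for inhibition of aldehyde dehydrogenase 1A1 (Homo sapiens), read by spectrophotometry, tested at 10 uM; on this read-out lower numbers stand for less inhibition and higher numbers for more inhibition at the one concentration tested (going by the name of the read-out).
Compound 2 `Cc1cccc(Cn2c(CN3CCN(C(=O)c4ccc(Cl)cc4)CC3)nc3ccccc32)c1` gives 23.2% in this assay.

For the measured compounds named here, compound 2 holds the lower of the two numbers measured so far, yet its nearest neighbour is compound 1, and the single step of a number 1.3 percentage points lower from compound 1 to compound 2 (within the scatter) lies within the scatter of this kind of measurement. On the numbers shown, then, compound 2 and compound 1 cannot be told apart.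

Compound 3 `Cc1cccc(Cn2c(CN3CCN(C(=O)c4ccc(Br)cc4)CC3)nc3ccccc32)c1` has not yet been measured. It differs from compound 2 by one change: bromo in place of chloro on an aromatic carbon. Going by the values given here, the only measured step, from pyridin-3-yl to 4-chlorophenyl on the carbonyl carbon, bears on this position and was small, a number 1.3 percentage points lower from compound 1 to compound 2 (within the scatter). Nothing measured separates a bromo from a chloro on that ring, so no direction can be read from the data; the expectation is that the exchange changes little in this assay, and the step of a number 0.8 percentage points higher from compound 2 to compound 3 (within the scatter) is estimated to stay within the scatter.

For compound 3 the estimate in this assay is therefore 24%, with a range from 12% to 38%.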

Compound 3, a percentage reported as inhibition, at one concentration (the size of the read-out at that concentration, not a potency): 25.8%
Estimate against measurement, compound 3: 1.8 percentage points below; the range from low to high includes it.
By their numbers in this assay, from the lowest: compounds 2, 1 and 3 (each within the scatter of the next).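

In this assay, for the compounds shown here, the step of a number 2.6 percentage points higher from compound 2 to compound 3 (within the scatter) is the first direct reading of a halogen exchange on the aromatic carbon para to a large group, and it shows that chloro and bromo cannot be told apart at this place. The step of a number 1.3 percentage points higher from compound 1 to compound 3 (within the scatter) extends this to the group on the carbonyl carbon, so that pyridin-3-yl, 4-chlorophenyl and 4-bromophenyl all lie within the scatter of one another, and no separation among these three groups can be read from these numbers. No measurement at hand offers any explanation for this result.

The compounds shown leave open whether a group of another kind at this place on the ring, such as an amine, a carboxylic acid or a longer alkyl chain, would give a number beyond the scatter of these three. They also leave open how far the reading depends on the rest of the shared core, such as the methyl group on its benzyl ring, and what potency lies behind these single-concentration readings.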